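Swapping the Para Substituent: Trifluoromethyl to Phenoxy

The source may report more compounds than this note shows. Statements on the series, on what has been measured and on what is new or still open speak of the compounds shown alone.

Going by the values given here, compound 2 `FC(F)(F)c1ccc(CO/N=C/c2c(-c3ccc4ccccc4c3)nc3occn23)cc1` gives 470 nM in an assay on HepG2 cells for agonist activity at nuclear receptor subfamily 1 group I member 3 (Homo sapiens), read by a luciferase reporter, with a stated time of 23 h (a lower number here means that less compound is needed, a higher number that more compound is needed for the effect), the lower of the two numbers measured so far, while compound 1 `COc1ccc(CO/N=C/c2c(-c3ccc4ccccc4c3)nc3occn23)cc1` gives 4400 nM. Among the compounds with values here, the single measured step, a 9.4-fold lower number from compound 1 to compound 2 (0.97 log units; beyond the scatter), shows that exchanging the group para to a large group moves the number substantially. Compound 3 `C(=N/OCc1ccc(Oc2ccccc2)cc1)\c1c(-c2ccc3ccccc3c2)nc2occn12` carries phenoxy in place of trifluoromethyl on an aromatic carbon. Within the data shown here, no measured step involves a phenoxy group, so its direction is open. Among the measured compounds shown here, because the only comparable change, a 9.4-fold lower number from compound 1 to compound 2 (0.97 log units; beyond the scatter), was modest, a shift of similar size either way is plausible. Compound 3 is expected near 900 nM, between 200 nM and 4000 nM. The expected step is a 1.9-fold higher number from compound 2 to compound 3 (0.28 log units; within the scatter).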

Compound 3, half-maximal effective concentration: "not active" (no number reported)
Compound 3 has no reported number here; the estimate stays without a comparison.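

Going by these compounds alone, compound 3 is reported as "not active" in this assay without a number, so no step from compound 2 to compound 3 can be read. On these data alone, how phenoxy compares with trifluoromethyl stays open. Nothing shown here explains this result.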